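Dropping the Methoxy Group: Compound 1 to Compound 3

The compounds below may be only part of what the source reports. "The series", "measured", "known", "first", "only" and "open" are said of these compounds alone.

Compound 1 `COc1ccc2nc(Nc3ccnc(Nc4ccc(S(N)(=O)=O)cc4)n3)sc2c1` is the stronger of the two measured compounds: in a functional assay on HeLa cells (Homo sapiens) for antiproliferative activity, read by MTT assay, with a stated time of 48 h (a higher number here means a weaker inhibitor, a lower number a stronger inhibitor), compound 1 gives 1730 nM, whereas compound 2 `Cc1cnc(Nc2ccc([N+](=O)[O-])cc2)nc1Nc1nc2ccccc2s1` gives 34300 nM in this assay, a gap well beyond the scatter. Compound 3 `NS(=O)(=O)c1ccc(Nc2nccc(Nc3nc4ccccc4s3)n2)cc1` differs from compound 1 by hydrogen in place of methoxy on an aromatic carbon. Among the measured compounds shown here, no measured pair isolates this change, so its effect is uncertain; the expected step in this assay is a 1.5-fold higher number from compound 1 to compound 3 (0.18 log units; within the scatter), a slight weakening that may lie within the scatter. Compound 3 is therefore estimated at 2600 nM, with a range of 900 nM to 7500 nM.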

Compound 3, half-maximal inhibitory concentration: 2060 nM
For compound 3 the middle estimate is 1.3-fold (0.10 log units) above the measured one; the measured number falls inside the stated range.
By their numbers in this assay, from the lowest: compounds 1 and 3 (each within the scatter of the next); then compound 2.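

In this assay, among the compounds shown here, hydrogen in place of methoxy gives a 1.2-fold higher number from compound 1 to compound 3 (0.08 log units; within the scatter) and this is the only measured pair that isolates the change. At this aromatic carbon, then, the methoxy group can be removed with no shift beyond the scatter, and the activity of compound 1 does not depend on it in this assay. No available measurement bears on the reason for this.

Going by these compounds, whether an amine, a fluorine or a longer chain such as butoxy on this carbon would move the number stays open. On these data alone, it also remains open whether other positions on the shared core tolerate change as readily.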